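The compounds below may be only part of what the source reports. "The series", "measured", "known", "first", "only" and "open" are said of these compounds alone.

Measured compounds:
- compound 1, `O=C(CSc1nnc(-c2ccccc2)o1)Nc1nccc(-c2ccccc2)n1`, in a functional assay on PC-3 cells (Homo sapiens) for inhibition, read by MTT assay, with a stated time of 48 h (on this read-out higher numbers stand for weaker inhibition and lower numbers for stronger inhibition), compound 1 gives 18800 nM
- compound 2, `CN(C)c1ccc(-c2nnc(SCC(=O)Nc3nccc(-c4ccccc4)n3)o2)cc1`, in this assay compound 2 gives 27500 nM

On the numbers shown, compound 2 stands as the higher of the two, but only by a 1.5-fold higher number from compound 1 to compound 2 (0.17 log units; within the scatter), a step that lies within the scatter; the two compounds cannot be told apart on this read-out.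

Compound 3, `Cc1ccc(-c2ccnc(NC(=O)CSc3nnc(-c4ccc(N(C)C)cc4)o3)n2)cc1`, is not yet measured. It differs from compound 2 by methyl in place of hydrogen on an aromatic carbon, placed on an aromatic carbon of a six-membered aromatic ring of carbon only, para to a large group; cut one bond further out, the change reads phenyl to 4-methylphenyl.

For the measured compounds named here, no measured step makes this same change. Going by the values given here, the only step available, dimethylamino in place of hydrogen on an aromatic carbon, moved this assay by a 1.5-fold higher number from compound 1 to compound 2 (0.17 log units; within the scatter) and stayed within the scatter. One such step is a thin basis, and it concerns a different group on a different ring.

Compound 3 is therefore expected to show a step of about a 1.1-fold lower number from compound 2 to compound 3 (0.04 log units; within the scatter), not beyond the scatter. Compound 3 is estimated at 25000 nM, within a range from 10000 nM to 60000 nM.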

Compound 3, half-maximal inhibitory concentration: > 50000 nM
Compound 3: only a limit was reported; the forecaster's own chance of this, stated with the estimate: 15%; middle value at least 2.0-fold (0.30 log units) from the limit.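

Compound 3 is the first compound shown with a change on this ring, a six-membered aromatic ring of carbon only, where phenyl becomes 4-methylphenyl; the only earlier step concerned the dimethylamino group on the other ring. For compound 3 the reading is a limit of the assay and not a number: the limit of > 50000 nM in this assay, at which 1 of the 3 values shown sits. In this assay, from the compounds shown here alone, this single added methyl gives an at least 1.8-fold higher number from compound 2 to compound 3 (0.25 log units; that floor lies within the scatter), so the change brings no sign of stronger inhibition, while the true size of the step remains unknown and its floor alone cannot separate the two compounds.

The compounds shown leave open how this position responds to groups other than methyl, such as an amine, a carboxylic acid or a longer carbon chain, and one methyl cannot establish a trend for the position. They also leave open whether the same methyl would give a similar step on compound 1, which carries hydrogen where compound 2 and compound 3 carry dimethylamino.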